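A Methyl Added to an Adenosine Receptor Binder

This account rests on a few compounds, and the source may have more. Where it says the series, first, only, none or still open, it means among the compounds named here.

Compound 1, `Nc1sc2c(c1C(=O)c1cccc3ccccc13)CCC2`: 8%
Compound 2, `Cc1sc(N)c(C(=O)c2ccc3ccccc3c2)c1C`: 0%
Compound 3, `Nc1sc2c(c1C(=O)c1ccc3ccccc3c1)CCC2`: 14.5%

All three were tested in an assay on isolated protein with adenosine receptor A1 (Homo sapiens) as the target, tested at 10 uM; on this read-out lower numbers stand for less inhibition and higher numbers for more inhibition at the one concentration tested (going by the name of the read-out). Compound 3 gives the highest of the three numbers, but its gap to compound 1 is within the usual scatter, while its gap to compound 2 lies beyond it. Compound 4, `Cc1cc(C(=O)c2c(N)sc3c2CCC3)cc2ccccc12`, has not yet been measured. It differs from compound 3 in one place: methyl in place of hydrogen on an aromatic carbon. Among the compounds with values here, no measured pair shows this kind of change, so the size of the step is unknown from the data. The step of a number 0.5 percentage points lower from compound 3 to compound 4 (within the scatter) is expected to be small, with no clear direction and likely none beyond the scatter. Compound 4 is therefore estimated at 14%, in a range from 0% to 35%.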

Compound 4, a percentage reported as inhibition, at one concentration (the size of the read-out at that concentration, not a potency): 6%
Compound 4: middle estimate off by 8 percentage points, on the high side, within the range that was stated.
By their numbers in this assay, from the lowest: compounds 2, 4, 1 and 3 (each within the scatter of the next, the first and the last beyond it).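

Putting methyl in place of hydrogen on an aromatic carbon gives a number 8.5 percentage points lower from compound 3 to compound 4 (within the scatter) in this assay. Within the data shown here, this is the first pair in the set that isolates this position, and its single added carbon produces no change that can be told from the scatter. Nothing measured here speaks to what the methyl does at this position.

As far as these compounds go, whether a chlorine atom, a methoxy group or a longer chain such as ethyl at this carbon would shift the number beyond the scatter remains open. So does the outcome of methyl on the other aromatic carbons of this ring.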